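The source may hold more compounds than are shown below. What is called first, only, known or untested is meant among the compounds shown, and "the series" means these compounds.

Compound 1 `CCCc1nc(C)c2c(C)nn(C)c(=O)n12` and compound 2 `CCCc1nc(C)c2cnn(C)c(=O)n12` share one core, while compound 3 `COCc1nc(C)c2cnnc(S)n12` and compound 4 `COCc1ncc2cnnc(S)n12` share another; the difference between the two cores is not broken down here. In a functional assay for inhibition, with Homo sapiens as the target (on this read-out higher numbers stand for weaker inhibition and lower numbers for stronger inhibition), compound 1 reaches only the assay limit, > 48000 nM. Compound 2 gives 20000 nM in this assay. As far as these compounds go, the change hydrogen in place of methyl on an aromatic carbon thus brought an at least 2.4-fold lower number from compound 1 to compound 2 (0.38 log units; beyond the scatter), a step that stays open-ended as compound 1 sits at the limit of > 48000 nM in this assay, at which 2 of the 3 values shown sit. For compound 3 the read-out in this assay is again only a limit, > 48000 nM. The change hydrogen in place of methyl on an aromatic carbon is the same kind of change, but it falls on a five-membered aromatic ring with 2 nitrogen rather than a six-membered aromatic ring with 3 nitrogen, and it is not ortho to a fused ring nor meta to a methyl group. By analogy with an at least 2.4-fold lower number from compound 1 to compound 2 (0.38 log units; beyond the scatter), the step is expected to be an at least 1.6-fold lower number from compound 3 to compound 4 (0.20 log units; that floor lies within the scatter). Compound 4 is therefore estimated at 30000 nM, between 10000 nM and 100000 nM.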

Compound 4, half-maximal inhibitory concentration: > 48000 nM
Compound 4 gave a limit, no number (the forecaster's own chance of this, stated with the estimate: 55%); at least 1.6-fold (0.20 log units) between middle value and limit.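

No step can be read from compound 3 to compound 4, because both give only a limit: the limit of > 48000 nM in this assay, at which 3 of the 4 values shown sit.

The compounds shown leave open whether hydrogen in place of methyl changes inhibition at all on the core of compound 3.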